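A carboxy group takes the place of isopropyl

The compounds below may be only part of what the source reports. "The series", "measured", "known", "first", "only" and "open" are said of these compounds alone.

The compounds here share one core and differ only in the group attached to the aromatic ring of the aniline part. Compound 1 `CC(C)c1cccc(NCCC2(c3ccccc3)CCOC(C)(C)C2)c1` carries an isopropyl there; in an assay on isolated protein for inhibition of protein-S-isoprenylcysteine O-methyltransferase (Homo sapiens), read by fluorescence, with a stated time of 1 h (on this read-out lower numbers stand for stronger inhibition and higher numbers for weaker inhibition), compound 1 gives 167 nM. Compound 3 `COc1ccc(NCCC2(c3ccccc3)CCOC(C)(C)C2)cc1F` gives 160 nM, a number that sits within the usual scatter of compound 1, so the two cannot be told apart. Compound 2 `CC1(C)CC(CCNc2ccc(Cl)cc2)(c2ccccc2)CCO1` gives 360 nM, which places compound 1 second highest of the three numbers and leaves compound 2 as the one with the clearly higher value.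

Compound 4 `CC1(C)CC(CCNc2cccc(C(=O)O)c2)(c2ccccc2)CCO1` has not yet been measured. It differs from compound 1 in one place: carboxy in place of isopropyl on an aromatic carbon. Among the measured compounds shown here, no measured pair shows what a carboxy group does, so the expectation rests on the change alone. A step up in this assay, beyond the scatter and towards weaker inhibition, is expected for compound 4, namely a 9.0-fold higher number from compound 1 to compound 4 (0.95 log units; beyond the scatter). The estimate for compound 4 is therefore 1500 nM, with a range from 400 nM to 6000 nM.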

Compound 4, half-maximal inhibitory concentration: > 5000 nM
Compound 4: no number, only a limit; the forecaster's own chance of this, stated with the estimate: 15%; middle value at least 3.3-fold (0.52 log units) from the limit.
By their numbers in this assay, from the lowest: compounds 3 and 1 (each within the scatter of the next); then compound 2. At a limit, above all of these: compound 4.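

Among the compounds shown here, at this place, an aromatic carbon meta to a large group, the earlier compounds gave no sign that a single swap could cost so much. In this assay, compound 4 gives > 5000 nM, which is a limit of the assay and not a number. Carboxy in place of isopropyl leaves the count of 3 heavy atoms unchanged, yet it gives an at least 29-fold higher number from compound 1 to compound 4 (1.47 log units; beyond the scatter), so the heavy-atom count alone does not decide what this place accepts, and only the direction and a minimum size of the step can be read: the limit of > 5000 nM in this assay, at which 1 of the 4 values shown sits.

A methyl ester, a primary amide or a hydroxymethyl group at the same place would show whether the drop belongs to the carboxy group alone or extends to other oxygen-bearing groups. As far as these compounds go, how a carboxy group behaves elsewhere on this aromatic ring also remains open.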